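One Ring Swap, Tested Twice for Cytotoxicity

This account rests on a few compounds, and the source may have more. Where it says the series, first, only, none or still open, it means among the compounds named here.

Compound 2 `O=C(CSc1nncnc1-c1ccccc1Cl)Nc1ccccc1[N+](=O)[O-]` and compound 1 `O=C(CSc1nncnc1-c1cccc2ccccc12)Nc1ccccc1[N+](=O)[O-]` differ in a single group. In an ADME assay on MT4 cells (Homo sapiens) for cytotoxicity, read by MTT assay (on this read-out higher numbers stand for lower toxicity in this test and lower numbers for higher toxicity in this test), compound 2 gives 63000 nM, while compound 1 gives 142000 nM. The difference between them is naphthalen-1-yl in place of 2-chlorophenyl on an aromatic carbon, and that change made a 2.3-fold higher number from compound 2 to compound 1 (0.35 log units; beyond the scatter).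

Compound 3 `CCOC(=O)c1ccc(NC(=O)CSc2nncnc2-c2ccccc2Cl)c(Br)c1` carries the same 2-chlorophenyl group on the shared core, but the rest of the molecule differs from compound 2; how the two cores differ is not broken down here. In this assay, going by the values given here, compound 3 gives 69000 nM, a number within the usual scatter of the one for compound 2.

Compound 4 `CCOC(=O)c1ccc(NC(=O)CSc2nncnc2-c2cccc3ccccc23)c(Br)c1` has not yet been measured. It is obtained from compound 3 by naphthalen-1-yl in place of 2-chlorophenyl on an aromatic carbon, the same change at the same place as before. A step of similar size is expected, namely a 2.1-fold higher number from compound 3 to compound 4 (0.32 log units; beyond the scatter), because the same change earlier gave a 2.3-fold higher number from compound 2 to compound 1 (0.35 log units; beyond the scatter). On that basis compound 4 is expected to give about 145000 nM, with a plausible range from 75000 nM to 290000 nM.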

Compound 4, half-maximal cytotoxic concentration: 105000 nM
Estimate against measurement, compound 4: 1.4-fold (0.14 log units) above; measured number inside the range.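

Carried onto the second core, the swap of 2-chlorophenyl for naphthalen-1-yl in this assay gives a 1.5-fold higher number from compound 3 to compound 4 (0.18 log units; within the scatter), so taken alone this step cannot be told apart from the ordinary variation between repeated measurements. Set beside the earlier step, the new one shows no real difference in the size of the effect: the same change on two cores in this assay, a 2.3-fold higher number (0.35 log units; beyond the scatter) from compound 2 to compound 1 and a 1.5-fold higher number (0.18 log units; within the scatter) from compound 3 to compound 4, 1.5-fold (0.17 log units) apart, within the scatter of two such steps

This means that the change behaves alike on these two cores as far as this test can tell, but two pairs of compounds do not establish a rule for the series, and they do not explain why the numbers come out as they do.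

The compounds shown leave open how a plain phenyl, or an aromatic ring carrying an amine or a carboxylic acid, would read at this same place on either core. They also leave open whether the swap would give a similar step on a third core.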